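The compounds below may be only part of what the source reports. "The series", "measured", "known", "first", "only" and "open" are said of these compounds alone.

Of the compounds shown here, three have been measured in a functional assay on L1210 cells (Mus musculus) for inhibition; a higher number here means a weaker inhibitor, a lower number a stronger inhibitor: compound 1 (`Cc1cn(C/C=C\CCl)c(=O)[nH]c1=O`), compound 2 (`NC1=NC(N)c2c(ncn2C=C=CCO)N1`) and compound 3 (`Nc1ncnc2c1ncn2C=C=CCCl`). Compound 1 gives 46000 nM, and compound 2 gives 60000 nM. Compound 3 gives 45000 nM, which stands within the scatter of both other values, so these three numbers do not separate the compounds from one another.

The next compound is compound 4 (`Nc1ncnc2c1ncn2/C=C\CCO`). Its structure differs from that of compound 3 in a single substituent, on an aromatic nitrogen: 4-hydroxybut-1-en-1-yl in place of 4-chlorobuta-1,2-dien-1-yl on an aromatic nitrogen. Thus 4-hydroxybut-1-en-1-yl stands in place of 4-chlorobuta-1,2-dien-1-yl.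

Within the data shown here, no measured pair isolates this change, so any expectation for it is a loose one. The closest guide is compound 2, which also has a chain ending in a hydroxy group, although on a different core, and which gives 60000 nM in this assay. On that evidence, no step beyond the scatter is expected, with at most a slight drift towards a weaker inhibitor. The expected change is a 1.3-fold higher number from compound 3 to compound 4 (0.12 log units; within the scatter). For compound 4 the estimated value is 60000 nM, with an expected range from 22000 nM to 160000 nM.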

Compound 4, half-maximal inhibitory concentration: 200000 nM
Compound 4: the middle estimate sits 3.3-fold (0.52 log units) below what was measured, outside the stated range (above it).
By their numbers in this assay, from the lowest: compounds 3, 1 and 2 (each within the scatter of the next); then compound 4.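

In this assay, among these compounds, putting 4-hydroxybut-1-en-1-yl in place of 4-chlorobuta-1,2-dien-1-yl on an aromatic nitrogen of the five-membered aromatic ring gives a 4.4-fold higher number from compound 3 to compound 4 (0.65 log units; beyond the scatter), the only step so far that lies beyond the scatter and one towards a weaker inhibitor. The earlier values sat within the scatter of one another and did not separate any compounds, whereas this pair shows that the chain on this nitrogen can shift the read-out, even between two chains of 5 heavy atoms each. Nothing available explains this step.

The change alters several things at once: a hydroxy group replaces the chlorine, the chain goes from 2 double bonds to 1, and a hydrogen-bond donor and acceptor enter, so the compounds shown do not say which of these carries the step. On these data alone, a 4-chlorobut-1-en-1-yl or a 4-hydroxybuta-1,2-dien-1-yl chain on the same core would separate these changes, and how an amine at the chain end or a longer chain would fare at this position remains open.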